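Cyclopropyl for Methyl on a Pyrazole Amine Series

This account rests on a few compounds, and the source may have more. Where it says the series, first, only, none or still open, it means among the compounds named here.

The study covers three measured compounds and one awaiting measurement in an assay for inhibition of high affinity nerve growth factor receptor (Homo sapiens), read by HTRF, with a stated time of 30 min, in the presence of a further agent that is not named here; a higher number here means a weaker inhibitor, a lower number a stronger inhibitor. Compound 1 `Cc1cc(Nc2nc(NCc3ccc(F)cc3F)nc3ccccc23)n[nH]1` gives 200 nM in this assay. Compound 2 `Fc1ccc(CNc2nc(Nc3cc(C4CC4)[nH]n3)c3ccccc3n2)c(F)c1` differs from compound 1 only by cyclopropyl in place of methyl on an aromatic carbon; compound 2 gives 4.7 nM, so that a 43-fold lower number from compound 1 to compound 2 (1.63 log units; beyond the scatter). Compound 3 `Cc1cc(Nc2nc(NCc3ccc(F)cc3F)nc3ccc(Cl)cc23)n[nH]1` carries a different core, the difference being (chloro in place of hydrogen on an aromatic carbon), and gives 520 nM, so that a 2.6-fold higher number from compound 1 to compound 3 (0.41 log units; beyond the scatter); compound 3 has the highest number of the three.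

Compound 4 `Fc1ccc(CNc2nc(Nc3cc(C4CC4)[nH]n3)c3cc(Cl)ccc3n2)c(F)c1` has the core of compound 3 and differs from it by cyclopropyl in place of methyl on an aromatic carbon. This is the same change as that from compound 1 to compound 2, at the same place in both pairs. For compound 4 the step is expected to be a 37-fold lower number from compound 3 to compound 4 (1.57 log units; beyond the scatter), of similar size to the earlier one, because a 43-fold lower number from compound 1 to compound 2 (1.63 log units; beyond the scatter) when the same change was made once before. Compound 4 is therefore expected to give about 14 nM in this assay, with a range from 5 nM to 40 nM.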

Compound 4, half-maximal inhibitory concentration: 72 nM
Estimate against measurement, compound 4: 5.1-fold (0.71 log units) below, and the stated range ends below it.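

In this assay cyclopropyl in place of methyl still lowers the number on the chloro-bearing core, with a 7.2-fold lower number from compound 3 to compound 4 (0.86 log units; beyond the scatter), but this step is smaller than the one on the core of compound 1: the same change on two cores in this assay, a 43-fold lower number (1.63 log units; beyond the scatter) from compound 1 to compound 2 and a 7.2-fold lower number (0.86 log units; beyond the scatter) from compound 3 to compound 4, 5.9-fold (0.77 log units) apart, beyond the scatter of two such steps. Seen from the other side of the same four compounds, chloro in place of hydrogen raises the number with a 15-fold higher number from compound 2 to compound 4 (1.19 log units; beyond the scatter), so the effects of the two changes do not simply add: the same change on two cores in this assay, a 2.6-fold higher number (0.41 log units; beyond the scatter) from compound 1 to compound 3 and a 15-fold higher number (1.19 log units; beyond the scatter) from compound 2 to compound 4, 5.9-fold (0.77 log units) apart, beyond the scatter of two such steps. The direction of the cyclopropyl step thus carried from one core to the other and its size did not, although two cores cannot show how the step would behave on a third, and these numbers alone do not explain the gap.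

The compounds shown leave open whether an ethyl or a tert-butyl group in place of the cyclopropyl would follow the same pattern on these two cores. They also leave open whether a fluoro or a methoxy group in place of the chloro would shrink the cyclopropyl step in the same way.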